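Methylamino to dimethylamino in an antiproliferative series

The source may report more compounds than this note shows. Statements on the series, on what has been measured and on what is new or still open speak of the compounds shown alone.

Of the compounds shown here, two have numbers so far. In a functional assay on MCF7 cells (Homo sapiens) for antiproliferative activity, read by MTT assay, with a stated time of 48 h (on this read-out higher numbers stand for weaker inhibition and lower numbers for stronger inhibition), compound 1 (`COc1ccc(C(=O)c2ccc(OC)c3c2OC(C)(C)C=C3)c(NC(=O)CN(C)C)c1`) gives 2680 nM, and compound 2 (`CNCC(=O)Nc1cc(OC)ccc1C(=O)c1cc(OC)c(OC)c(OC)c1`) gives 550 nM. Compound 2 holds the lower of the two values, and the gap to compound 1 lies beyond the scatter, so compound 2 is the stronger inhibitor of this pair. The two compounds differ in more than one place, so their gap cannot be assigned to any single change.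

Compound 3 (`COc1ccc(C(=O)c2cc(OC)c(OC)c(OC)c2)c(NC(=O)CN(C)C)c1`) has not yet been measured. It departs from compound 2 by methyl in place of hydrogen on an amine nitrogen. Methylamino becomes dimethylamino, and the rest of the structure stays the same. Going by the values given here, no measured pair shows this change alone, so the expectation rests only on the value of compound 2, 550 nM, and on the small size of the change. In this assay, no shift beyond the scatter is expected, in either direction. The expected 1.1-fold lower number from compound 2 to compound 3 (0.04 log units; within the scatter) is estimated to stay within that scatter. Compound 3 is expected at about 500 nM, with an estimated range of 170 nM to 1500 nM.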

Compound 3, half-maximal inhibitory concentration: 790 nM
Compound 3: the middle estimate sits 1.6-fold (0.20 log units) below what was measured; the measured number falls inside the stated range.
By their numbers in this assay, from the lowest: compounds 2 and 3 (each within the scatter of the next); then compound 1.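

In this assay, going by these compounds alone, the first pair of the series that differs in one place gives a 1.4-fold higher number from compound 2 to compound 3 (0.16 log units; within the scatter), so replacing methylamino with dimethylamino leaves the read-out within the scatter. On this core, the amine nitrogen whose other neighbours are saturated chain carbons carries either one or two methyl groups with no separable change in antiproliferative activity, and compound 2 and compound 3 stand at one level for working purposes. No measurement is available that would explain this flat step, and the pair itself offers only the size of the step.

Still open, on these data alone, is whether this flat reading extends beyond methyl: a primary amine, an ethyl group on the same nitrogen, or a cyclic amine such as pyrrolidine could each read differently. Also open, as far as these compounds go, is whether the same change would read alike on the core of compound 1, which carries dimethylamino and gives 2680 nM, since a step measured on one core need not carry over to another.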